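This account rests on a few compounds, and the source may have more. Where it says the series, first, only, none or still open, it means among the compounds named here.

Compound 1 `COc1ccccc1-c1ccc2ncn(-c3cc(OC)c(OC)c(OC)c3)c2c1`: 4320 nM
Compound 2 `COc1cc(-n2cnc3ccc(-c4cccc(C)c4)cc32)cc(OC)c1OC`: 3820 nM

In a functional assay on A549 cells (Homo sapiens) for antiproliferative activity, read by MTT assay, with a stated time of 72 h (on this read-out lower numbers stand for stronger inhibition and higher numbers for weaker inhibition), compound 1 gives 4320 nM, and compound 2 gives 3820 nM. Compound 2 stands at the lowest of the two numbers measured, with compound 1 its nearest neighbour, but the step between them is a 1.1-fold lower number from compound 1 to compound 2 (0.05 log units; within the scatter), so the two values cannot be told apart and neither compound can be called the more potent.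

Compound 3 `COc1cc(-n2cnc3ccc(-c4ccc(Cl)cc4)cc32)cc(OC)c1OC` differs from compound 2 by one change: 4-chlorophenyl in place of 3-methylphenyl on an aromatic carbon. Within the data shown here, the only measured step that bears on this position is the one between compound 1 and compound 2, a 1.1-fold lower number from compound 1 to compound 2 (0.05 log units; within the scatter), which lies within the scatter. Among the measured compounds shown here, that single step gives no sign that swapping the substituent on this aromatic carbon moves the number in this assay by more than the scatter, although only one such swap has been measured.

Compound 3 is therefore expected to give about 3500 nM in this assay, within a range from 1500 nM to 9000 nM. The expected step for compound 3 is a 1.1-fold lower number from compound 2 to compound 3 (0.04 log units; within the scatter), that is, no change beyond the scatter.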

Compound 3, half-maximal inhibitory concentration: > 10000 nM
Compound 3: no number, only a limit; the forecaster's own chance of this, stated with the estimate: 5%; at least 2.8-fold (0.45 log units) between middle value and limit.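

In this assay, this aromatic carbon is no longer indifferent to the group it carries: 4-chlorophenyl in place of 3-methylphenyl gives an at least 2.6-fold higher number from compound 2 to compound 3 (0.41 log units; beyond the scatter), and 4-chlorophenyl in place of 2-methoxyphenyl gives an at least 2.3-fold higher number from compound 1 to compound 3 (0.36 log units; beyond the scatter), whereas the earlier swap gave only a 1.1-fold lower number from compound 1 to compound 2 (0.05 log units; within the scatter). Two different aryl groups on the shared core thus read alike, while compound 3, with its 4-chlorophenyl group, stands apart from both, so a swap at this place can move the number beyond the scatter towards weaker inhibition. The reading for compound 3 is a limit of the assay and not a number, so these steps fix only the smallest size of the change, and its full size stays unknown: the limit of > 10000 nM in this assay, at which 1 of the 3 values shown sits.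

The compounds shown leave open whether the chlorine itself or its place on the phenyl ring accounts for the step, and a 3-chlorophenyl or a 4-methylphenyl group would be needed to separate the two. They also leave open how this position would respond to a 4-aminophenyl or a 4-carboxyphenyl group.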